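Replacing the Benzothiophene Amide with a Cinnamamide

This account rests on a few compounds, and the source may have more. Where it says the series, first, only, none or still open, it means among the compounds named here.

Compound 3 `CN1[C@@H]2c3[nH]c4ccccc4c3C[C@H]1[C@H](C#N)N1[C@@H](CNC(=O)c3cc4ccccc4s3)c3[nH]c4ccccc4c3C[C@@H]21` carries a 1-benzothiophen-2-yl group on the carbonyl carbon of its amide. In a functional assay on HT-29 cells (Homo sapiens) for cytotoxicity, read by MTT assay, with a stated time of 72 h (on this read-out lower numbers stand for stronger inhibition and higher numbers for weaker inhibition), compound 3 gives 640 nM, the second highest of the three numbers measured. Compound 1 `CN1[C@@H]2c3[nH]c4ccccc4c3C[C@H]1[C@H](C#N)N1[C@@H](CNC(=O)c3cccc(C(F)(F)F)c3)c3[nH]c4ccccc4c3C[C@@H]21`, with 3-(trifluoromethyl)phenyl on that carbonyl carbon, gives 140 nM in this assay, and the change is a 4.6-fold higher number from compound 1 to compound 3 (0.66 log units; beyond the scatter). Compound 2 `CN1[C@@H]2c3[nH]c4ccccc4c3C[C@H]1[C@H](C#N)N1[C@@H](CNC(=O)c3ccc4ccccc4c3)c3[nH]c4ccccc4c3C[C@@H]21`, bearing naphthalen-2-yl, gives 4940 nM in this assay; the step is a 7.7-fold lower number from compound 2 to compound 3 (0.89 log units; beyond the scatter), while between the two measured neighbours of compound 3 the step is a 35-fold higher number from compound 1 to compound 2 (1.55 log units; beyond the scatter).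

Compound 4 `CN1[C@@H]2c3[nH]c4ccccc4c3C[C@H]1[C@H](C#N)N1[C@@H](CNC(=O)/C=C/c3ccccc3)c3[nH]c4ccccc4c3C[C@@H]21` has not been measured: 2-phenylethenyl in place of 1-benzothiophen-2-yl on a carbonyl carbon. Among the compounds with values here, none of the measured steps involves the entering group, so its effect can only be bracketed. The two groups with a fused second ring gave the two higher numbers, whereas compound 1, with a single six-membered ring, gives 140 nM. Because compound 1 gives 140 nM, a move toward that number is anticipated, and a modest downward step is expected, a 1.6-fold lower number from compound 3 to compound 4 (0.20 log units; within the scatter). The estimate for compound 4 in this assay is 400 nM, expected to fall between 120 nM and 1800 nM.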

Compound 4, half-maximal inhibitory concentration: 1400 nM
Compound 4: the middle estimate sits 3.5-fold (0.54 log units) below what was measured, and the stated range covers the measured number.
By their numbers in this assay, from the lowest: compound 1; then compound 3; then compound 4; then compound 2.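

With 2-phenylethenyl on the carbonyl carbon, the entering group has a single six-membered aromatic ring, as 3-(trifluoromethyl)phenyl does, yet in this assay the number rises: a 10-fold higher number from compound 1 to compound 4 (1.00 log units; beyond the scatter). The new group instead falls among the two fused groups, with a 2.2-fold higher number from compound 3 to compound 4 (0.34 log units; beyond the scatter) and a 3.5-fold lower number from compound 2 to compound 4 (0.55 log units; beyond the scatter), so the presence of a single six-membered ring does not by itself give the lowest number, and 2-phenylethenyl goes against a split of these groups by fused second ring alone. Nothing measured here accounts for this order.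

The compounds shown leave open what a plain phenyl group or a saturated 2-phenylethyl chain would give on this carbonyl carbon. Also open, as far as these compounds go, is whether a trifluoromethyl group on the ring of 2-phenylethenyl would lower the number.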